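This account rests on a few compounds, and the source may have more. Where it says the series, first, only, none or still open, it means among the compounds named here.

Of the compounds shown here, two with the same core have been measured in a physicochemical assay for solubility; a lower number here means a less soluble compound, a higher number a more soluble compound: compound 1 `CNC(=O)c1cc(C(=O)N[C@H]2CC[C@H](O)CC2)cc2c1OC[C@@]2(C)c1ccccc1` and compound 2 `CNC(=O)c1cc(C(=O)N[C@H]2[C@@H]3COC[C@@H]32)cc2c1OC[C@@]2(C)c1ccccc1`. Compound 1 gives >= 161 ug/mL, which is a limit of the assay. Compound 2 gives >= 147 ug/mL, also a limit, and that limit is all that is known of where compound 2 stands. The next case is compound 3 `CNC(=O)c1cc(C(=O)N[C@H]2C[C@@H]2C)cc2c1OC[C@@]2(C)c1ccccc1`, which keeps the core and changes one group: a group of 4 heavy atoms (4 carbon; one three-membered non-aromatic ring of carbon only) in place of a group of 6 heavy atoms (5 carbon, 1 oxygen; one three-membered non-aromatic ring of carbon only, one five-membered non-aromatic ring with 1 hetero atom), on an amide-type nitrogen. For the measured compounds named here, the one measured step that bears on this change is a step that the two limits leave unreadable from compound 1 to compound 2, so it offers no size to carry over. The expectation in this assay therefore rests on the structural change alone, and it is a modest fall, with the estimated step being an at least 1.3-fold lower number from compound 2 to compound 3 (0.12 log units; that floor lies within the scatter). The estimate for compound 3 is 110 ug/mL, with an expected range from 40 ug/mL to 190 ug/mL.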

Compound 3, solubility: 3 ug/mL
Compound 3: the middle estimate sits 37-fold (1.56 log units) above what was measured; measured number outside the range, below it.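

On an amide-type nitrogen, the choice of group can change the number in this assay greatly, which the two earlier compounds could not show because each gave only a limit. Placing 2-methylcyclopropyl there instead of the group in compound 2 gives an at least 49-fold lower number from compound 2 to compound 3 (1.69 log units; beyond the scatter), and placing it there instead of 4-hydroxycyclohexyl gives an at least 53-fold lower number from compound 1 to compound 3 (1.72 log units; beyond the scatter). Nothing measured here says why the number falls so far.

Both groups that leave hold an oxygen and the group that enters holds none, but these compounds cannot separate that difference from the differences in size and ring. A hydroxymethyl-substituted cyclopropyl or a piperidin-4-yl group on the same nitrogen would show whether a small ring can keep a high number when it carries an oxygen or a nitrogen.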